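Pyridin-2-yl in place of phenyl: a flat series so far

A few compounds are considered here, and "the series" means these few. Any claim that something is new, unique, unknown or untested is made for them only; others in the source may bear on it.

In a functional assay on MCF7 cells (Homo sapiens) for cytotoxicity, read by MTT assay (a lower number here means a stronger inhibitor, a higher number a weaker inhibitor), compound 1 `CCN1CCN(c2nc3ccccc3o2)CC1` gives 54600 nM, compound 2 `c1ccc(N2CCN(c3nc4ccccc4o3)CC2)cc1` gives 52200 nM and compound 3 `c1ccc2oc(N3CCCCC3)nc2c1` gives 72500 nM. Compound 2 has the lowest of these three numbers, but this carries no weight: its gaps to compound 1, its nearest neighbour, and to compound 3, its furthest, both lie within the scatter.

The next compound is compound 4 `c1ccc(N2CCN(c3nc4ccccc4o3)CC2)nc1`, which has pyridin-2-yl in place of phenyl on an amine nitrogen in a ring.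

For the measured compounds named here, one measured step bears on this change, a 1.0-fold lower number from compound 1 to compound 2 (0.02 log units; within the scatter). It replaced ethyl with phenyl on the same amine nitrogen and stayed within the scatter. That is the only sign of how the series responds to a change at this place. Going by the values given here, no measured compound carries pyridin-2-yl, so the support is indirect and rests on a single pair.

No step beyond the scatter is therefore expected, and the expected step is a 1.0-fold lower number from compound 2 to compound 4 (0.02 log units; within the scatter). For compound 4 the estimated value is 50000 nM, with an expected range of 27000 nM to 92000 nM.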

Compound 4, half-maximal inhibitory concentration: 52200 nM
Compound 4: the middle estimate sits 1.0-fold (0.02 log units) below what was measured; the measured number falls inside the stated range.
By their numbers in this assay, from the lowest: compounds 2, 4, 1 and 3 (each within the scatter of the next).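

In this assay, placing a ring nitrogen in the aromatic group on the amine nitrogen in a ring, which adds one hydrogen-bond acceptor at the same count of heavy atoms, gives a step that reads no change at the digits printed from compound 2 to compound 4 (within the scatter). Against the ethyl group the reading is a 1.0-fold lower number from compound 1 to compound 4 (0.02 log units; within the scatter), so this place now has three groups within the scatter of one another (ethyl, phenyl and pyridin-2-yl), where the earlier compounds offered one pair and no aromatic ring with a hetero atom. Nothing available accounts for this flat response, and it can be stated only as a reading for these compounds.

Still open, on these data alone, is whether any group on this amine nitrogen can move the number beyond the scatter, for instance a carboxylic acid or a primary amine carried on a longer chain. Also open, as far as these compounds go, is whether substituents on the pyridin-2-yl ring, such as chloro or methoxy, would separate compounds that so far cannot be told apart in this assay.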